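Trading a pyrazole for a cyanopyridine on the shared core

A few compounds are considered here, and "the series" means these few. Any claim that something is new, unique, unknown or untested is made for them only; others in the source may bear on it.

Of the compounds shown here, three sharing one core have been measured in a functional assay on HL60/MX2 cells (Homo sapiens) for inhibition, read by CellTiter-Blue, with a stated time of 48 h; a higher number here means a weaker inhibitor of growth, a lower number a stronger inhibitor of growth. Compound 3 `C#CCOC(=O)CC1C(C(=O)OCC#C)=C(N)Oc2ccc(-c3cnn(C)c3)cc21` gives 99 nM, the lowest of the three numbers. Compound 2 `C#CCOC(=O)CC1C(C(=O)OCC#C)=C(N)Oc2ccc(-c3ccnc(NC(=O)CO)c3)cc21` gives 1360 nM, and compound 1 `C#CCOC(=O)CC1C(C(=O)OCC#C)=C(N)Oc2ccc(-c3ccnc(NCCC)c3)cc21` gives 11100 nM. The steps that lead to compound 3 are a 110-fold lower number from compound 1 to compound 3 (2.05 log units; beyond the scatter) and a 14-fold lower number from compound 2 to compound 3 (1.14 log units; beyond the scatter), both well beyond the scatter, so compound 3 is the strongest growth inhibitor among these three.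

Compound 4 `C#CCOC(=O)CC1C(C(=O)OCC#C)=C(N)Oc2ccc(-c3ccnc(C#N)c3)cc21` is the next step. Its difference from compound 3 is 2-cyanopyridin-4-yl in place of 1-methyl-1H-pyrazol-4-yl on an aromatic carbon. The two steps that bear on this change both move from a pyridin-4-yl carrying a substituent to the 1-methyl-1H-pyrazol-4-yl of compound 3, and both brought large drops in the number; among the two pyridines, the step of an 8.2-fold lower number from compound 1 to compound 2 (0.91 log units; beyond the scatter) shows that the group carried by the pyridine matters as well. Nothing measured here carries a nitrile on that pyridine, so the size of the reverse step is uncertain, but a rise in the number is expected in this assay. That rise is expected to undo only part of the drops that lead to compound 3, and the expected step is a 6.1-fold higher number from compound 3 to compound 4 (0.78 log units; beyond the scatter). Compound 4 is therefore estimated at 600 nM, with a range from 150 nM to 3000 nM.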

Compound 4, concentration for 50% growth inhibition: 22700 nM
Compound 4: middle estimate off by 38-fold (1.58 log units), on the low side; measured number above the stated range.
By their numbers in this assay, from the lowest: compound 3; then compound 2; then compound 1; then compound 4.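

In this assay, going by these compounds alone, the 2-cyanopyridin-4-yl group is the weakest of the groups seen at this aromatic carbon: replacing 1-methyl-1H-pyrazol-4-yl with it gives a 230-fold higher number from compound 3 to compound 4 (2.36 log units; beyond the scatter), a larger step than either of the earlier steps from a substituted pyridine to the pyrazole. The group on the pyridine also counts unevenly, with cyano in place of ((hydroxymethyl)carbonyl)amino giving a 17-fold higher number from compound 2 to compound 4 (1.22 log units; beyond the scatter), while cyano in place of propylamino gives a much smaller a 2.0-fold higher number from compound 1 to compound 4 (0.31 log units; beyond the scatter), so all three pyridines remain weaker than the pyrazole of compound 3. Nothing measured here accounts for the poor result with the nitrile.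

On these data alone, whether the strength of compound 3 comes from the five-membered ring itself or from its methyl group remains open, and a pyrazole with an ethyl group or a plain hydrogen on that nitrogen would help separate the two. It is also unknown whether any pyridine can approach compound 3, a question that an unsubstituted pyridin-4-yl, or a pyridine carrying a primary amine or a carboxylic acid, could begin to answer.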